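The compounds below may be only part of what the source reports. "The series", "measured", "known", "first", "only" and "open" are said of these compounds alone.

Two compounds share one core and differ only in the group on an aromatic carbon of the ring that carries the amino group. Compound 1 `Nc1cc(C2CCCC2)nc2ccc(NC(=O)/C=C/c3ccc(C(F)(F)F)cc3)cc12` bears a cyclopentyl there, and in a functional assay on HEK293 cells for activation of melanin-concentrating hormone receptor 1 (Homo sapiens), read by inositol phosphate accumulation (a lower number here means that less compound is needed, a higher number that more compound is needed for the effect), compound 1 gives 68 nM. Compound 2 `Cc1cc(N)c2cc(NC(=O)/C=C/c3ccc(C(F)(F)F)cc3)ccc2n1` bears a methyl in the same place, and in this assay compound 2 gives 140 nM. The step of a 2.1-fold higher number from compound 1 to compound 2 (0.31 log units; beyond the scatter) is the only one measured so far, and it leaves compound 2 with the highest of the two numbers, compound 1 standing nearest to it.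

Compound 3 `Nc1cc(-c2ccccc2)nc2ccc(NC(=O)/C=C/c3ccc(C(F)(F)F)cc3)cc12` is not yet measured. Relative to compound 2 it differs as phenyl in place of methyl on an aromatic carbon. Among the measured compounds shown here, the one relevant step shows that replacing methyl by a larger ring at this carbon, as in compound 1, lowered the number, so a similar modest move in the same direction is expected here for compound 3, namely a 2.2-fold lower number from compound 2 to compound 3 (0.33 log units; beyond the scatter). Compound 3 is therefore estimated to give 65 nM in this assay, with a range from 20 nM to 200 nM.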

Compound 3, half-maximal effective concentration: 6600 nM
Estimate against measurement, compound 3: 100-fold (2.01 log units) below; the measured number lies above the stated range.
By their numbers in this assay, from the lowest: compound 1; then compound 2; then compound 3.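

At this carbon, next to the ring nitrogen, the choice of group matters far more than the first comparison suggested: in this assay phenyl in place of methyl gives a 47-fold higher number from compound 2 to compound 3 (1.67 log units; beyond the scatter) and phenyl in place of cyclopentyl gives a 97-fold higher number from compound 1 to compound 3 (1.99 log units; beyond the scatter) on the same shared core. The presence of a ring at this position therefore does not set the number on its own, since compound 1 with its cyclopentyl has the lowest number of the three, while compound 3 with its phenyl has the highest, and compound 2 with its methyl, which has no ring, lies between them. Nothing available here accounts for the wide gap between the two ring-bearing compounds.

The compounds shown leave open whether a cyclohexyl or a cyclopentenyl group would stay close to cyclopentyl in this assay, or whether a pyridyl ring would fall as far as phenyl does. They also leave open whether a fluorine or a methoxy group on the phenyl, or a benzyl group in its place, would recover any of the loss seen with compound 3.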